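Swapping a methoxy for a fluoro on a piperazine aryl cap

A few compounds are considered here, and "the series" means these few. Any claim that something is new, unique, unknown or untested is made for them only; others in the source may bear on it.

Compounds measured so far:
- compound 1, `O=C(CCN1C(=O)CSc2ccccc21)N1CCN(c2ccccc2F)CC1`: 1600 nM
- compound 2, `COc1ccccc1N1CCN(CCCNC(=O)CCN2C(=O)CSc3ccccc32)CC1`: 2000 nM

Both compounds share a core that carries a propanamide arm ending in an aryl piperazine. In a functional assay on MDA-MB-231 cells (Homo sapiens) for inhibition, read by sulforhodamine B assay, with a stated time of 48 h (a higher number here means a weaker inhibitor of growth, a lower number a stronger inhibitor of growth), compound 1 gives 1600 nM, and compound 2 gives 2000 nM. Compound 2 has the highest number of the two, but its nearest neighbour is compound 1, and the gap between them lies within the scatter of the method, so no order between the two can be read from these values.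

Compound 3, `O=C(CCN1C(=O)CSc2ccccc21)NCCCN1CCN(c2ccccc2F)CC1`, is the next step. Starting from compound 2, the change is fluoro in place of methoxy on an aromatic carbon, on an aromatic carbon of the six-membered aromatic ring, ortho to a large group; cut one bond further out it reads as 2-methoxyphenyl to 2-fluorophenyl. Among the measured compounds shown here, no measured pair shows this change on its own, and the only other fluoro compound, compound 1, differs from compound 2 in more than one place. With both measured numbers so close, the expected step from compound 2 to compound 3 in this assay is a 1.1-fold lower number from compound 2 to compound 3 (0.05 log units; within the scatter), nothing beyond the scatter in either direction. Compound 3 is therefore estimated at 1800 nM, with a range from 900 nM to 3600 nM.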

Compound 3, concentration for 50% growth inhibition: 4600 nM
Beside the measured number, compound 3's estimate is 2.6-fold (0.41 log units) below it; measured number above the stated range.
By their numbers in this assay, from the lowest: compounds 1 and 2 (each within the scatter of the next); then compound 3.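

Among the compounds shown here, this pair gives the first comparison in which only one place changes. In this assay, fluoro in place of methoxy, on an aromatic carbon ortho to a large group, gives a 2.3-fold higher number from compound 2 to compound 3 (0.36 log units; beyond the scatter), a modest step but one beyond the scatter, so growth inhibition in these cells does respond to the group at this place, and the 2-methoxyphenyl form is the stronger inhibitor of this pair. The swap replaces a group counted with one hydrogen-bond acceptor by one counted with none, but nothing measured here explains the weaker inhibition.

One pair cannot show whether the answer follows the size of the group, its atoms or something else, and a chloro, methyl or hydroxy group at the same place would help to separate these possibilities. From the compounds shown here alone, it also remains open whether the step would keep its direction and size on the arm of compound 1, which would take a 2-methoxyphenyl partner for compound 1 to test.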